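Carbamate Extension of Compound 1 Toward Compound 3

The source may hold more compounds than are shown below. What is called first, only, known or untested is meant among the compounds shown, and "the series" means these compounds.

Among the compounds with values here, compound 1, `COc1nc(C)c(Nc2nc(Cl)cn([C@H](CO)C3CC3)c2=O)cc1C`, gives 88 nM in an assay on frontal cortex for displacement of a labelled ligand from corticotropin-releasing factor receptor 1 (Rattus norvegicus), with a stated time of 2 h (on this read-out lower numbers stand for stronger inhibition and higher numbers for weaker inhibition), the highest of the two numbers measured so far. Compound 2, `COc1nc(C)c(Nc2nc(Cl)cn([C@H](COC(=O)Nc3cc(Cl)cc(Cl)c3)C3CC3)c2=O)cc1C`, gives 1.7 nM in this assay. Within the data shown here, the single measured step, a 52-fold lower number from compound 1 to compound 2 (1.71 log units; beyond the scatter), came from a (3,5-dichlorophenyl)carbamoyl in place of hydrogen on an oxygen on a saturated carbon. Compound 3, `COc1ccc(NC(=O)OC[C@H](C2CC2)n2cc(Cl)nc(Nc3cc(C)c(OC)nc3C)c2=O)c(C)n1`, differs from compound 1 by (6-methoxy-2-methylpyridin-3-yl)carbamoyl in place of hydrogen on an oxygen on a saturated carbon. Because a 52-fold lower number from compound 1 to compound 2 (1.71 log units; beyond the scatter) was seen for a related carbamoyl at the same oxygen, a large step toward lower numbers is expected for compound 3, though the aromatic part differs. Compound 3 is therefore estimated at 6 nM, within 1.5 nM to 25 nM, that is a 15-fold lower number from compound 1 to compound 3 (1.17 log units; beyond the scatter).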

Compound 3, half-maximal inhibitory concentration: 9.2 nM
Compound 3: middle estimate off by 1.5-fold (0.19 log units), on the low side; the measured number falls inside the stated range.
By their numbers in this assay, from the lowest: compound 2; then compound 3; then compound 1.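

In this assay a second carbamoyl on this oxygen also lowers the number, with a 9.6-fold lower number from compound 1 to compound 3 (0.98 log units; beyond the scatter) beyond the scatter, so the drop is not confined to the (3,5-dichlorophenyl)carbamoyl. The aromatic group on the amide-type nitrogen also matters: 6-methoxy-2-methylpyridin-3-yl in place of 3,5-dichlorophenyl gives a 5.4-fold higher number from compound 2 to compound 3 (0.73 log units; beyond the scatter) in the same assay. Nothing available explains either step.

The compounds shown leave open whether an aromatic ring on the carbamoyl is needed at all, which a methylcarbamoyl or an acetyl on the same oxygen would test.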